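Swapping the dichlorophenyl arm for a hydroxynaphthyl

A few compounds are considered here, and "the series" means these few. Any claim that something is new, unique, unknown or untested is made for them only; others in the source may bear on it.

Of the compounds shown here, three sharing one core have been measured in a functional assay on NCI-H460 cells (Homo sapiens) for cytotoxicity, read by MTT assay, with a stated time of 72 h; a lower number here means a stronger inhibitor, a higher number a weaker inhibitor. Compound 1 `CN(C)CCn1cnnc1-c1cc(Oc2ccc(NC(=O)N/N=C/c3c[nH]c4ccccc34)cc2F)ccn1` gives 1630 nM. Compound 2 `COc1ccc(OC)c(/C=N/NC(=O)Nc2ccc(Oc3ccnc(-c4nncn4CCN(C)C)c3)c(F)c2)c1` gives 2930 nM. Compound 3 `CN(C)CCn1cnnc1-c1cc(Oc2ccc(NC(=O)N/N=C/c3cccc(Cl)c3Cl)cc2F)ccn1` gives 72 nM, the lowest number of the three, and its distance to the others is clear: the change from compound 1 to compound 3 amounts to a 23-fold lower number from compound 1 to compound 3 (1.35 log units; beyond the scatter), and that from compound 2 to compound 3 amounts to a 41-fold lower number from compound 2 to compound 3 (1.61 log units; beyond the scatter), whereas compound 1 and compound 2 differ only by a 1.8-fold higher number from compound 1 to compound 2 (0.25 log units; within the scatter).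

The next compound, compound 4 `CN(C)CCn1cnnc1-c1cc(Oc2ccc(NC(=O)N/N=C/c3c(O)ccc4ccccc34)cc2F)ccn1`, carries the change (2-hydroxynaphthalen-1-yl in place of 2,3-dichlorophenyl on a carbon with a double bond to nitrogen). The two measured steps that bear on it run the other way: whenever the 2,3-dichlorophenyl was replaced by another aromatic group on that same carbon, whether the 1H-indol-3-yl of compound 1 or the 2,5-dimethoxyphenyl of compound 2, the number rose sharply. The 2-hydroxynaphthalen-1-yl is a third such replacement, so a large rise is the reasonable expectation, although its exact size is uncertain.

In this assay the step to compound 4 is estimated at a 21-fold higher number from compound 3 to compound 4 (1.32 log units; beyond the scatter). Compound 4 is accordingly expected to give 1500 nM, with a likely range from 300 nM to 7000 nM.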

Compound 4, half-maximal inhibitory concentration: 890 nM
Compound 4: middle estimate off by 1.7-fold (0.23 log units), on the high side, and the stated range covers the measured number.
By their numbers in this assay, from the lowest: compound 3; then compounds 4, 1 and 2 (each within the scatter of the next, the first and the last beyond it).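

In this assay, the 2-hydroxynaphthalen-1-yl arm gives a 12-fold higher number from compound 3 to compound 4 (1.09 log units; beyond the scatter), so a group with two aromatic rings and a hydroxyl does not keep the low number of the 2,3-dichlorophenyl arm. This makes a third replacement on the carbon with a double bond to nitrogen that falls clearly short of compound 3, which now stands apart from all three other compounds, and these replacements share no obvious feature beyond being aromatic. They are not fully equivalent, however: the measured step of a 3.3-fold lower number from compound 2 to compound 4 (0.52 log units; beyond the scatter) is a modest gain over the 2,5-dimethoxyphenyl arm, whereas a 1.8-fold lower number from compound 1 to compound 4 (0.26 log units; within the scatter) leaves compound 4 and the indole compound within the scatter of each other.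

Nothing supplied here explains why the 2,3-dichlorophenyl arm stands out. The compounds shown also leave open how much of its advantage depends on the chlorine atoms, a question that a plain phenyl, a phenyl carrying a single chlorine and a phenyl carrying two fluorines on this same carbon would help to answer.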